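A few compounds are considered here, and "the series" means these few. Any claim that something is new, unique, unknown or untested is made for them only; others in the source may bear on it.

Compound 1 `CC(C)N(CCN(C(=O)Nc1cc(Cl)nc(Cl)c1)C1CC[C@]2(c3cccc(C#N)c3)CC2C1)C(C)C`: 2.4 nM in a functional assay for antagonist activity at melanin-concentrating hormone receptor 1 (Homo sapiens); a higher number here means a weaker inhibitor, a lower number a stronger inhibitor
Compound 2 `CC(C)NCCN(C(=O)Nc1cc(Cl)nc(Cl)c1)C1CC[C@]2(c3cccc(C#N)c3)CC2C1`: 1.9 nM

Of the two numbers in this assay, compound 2 has the lower one, yet a 1.3-fold lower number from compound 1 to compound 2 (0.10 log units; within the scatter) lies within the scatter, so the two stand level. Compound 3 `CC1CC[C@@H](CO)N1CCN(C(=O)Nc1cc(Cl)nc(Cl)c1)C1CC[C@]2(c3cccc(C#N)c3)CC2C1` carries 2-(hydroxymethyl)-5-methylpyrrolidin-1-yl in place of isopropylamino on a saturated chain carbon, two bonds along the chain from an amide-type nitrogen. Only the change from compound 1 to compound 2 bears on this; it also altered the amine nitrogen on that chain and stayed within the scatter. The entering group is a ring rather than an open chain, so that precedent is a loose guide and no direction is indicated. Compound 3 is therefore expected close to compound 2, with a 1.6-fold higher number from compound 2 to compound 3 (0.20 log units; within the scatter). The estimate for compound 3 is 3 nM (1 nM to 10 nM).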

Compound 3, inhibition constant: 1.2 nM
Compound 3: middle estimate off by 2.5-fold (0.40 log units), on the high side, within the range that was stated.
By their numbers in this assay, from the lowest: compounds 3, 2 and 1 (each within the scatter of the next).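

In this assay the amine on this chain can be a ring as well as an open chain: 2-(hydroxymethyl)-5-methylpyrrolidin-1-yl in place of isopropylamino gives a 1.6-fold lower number from compound 2 to compound 3 (0.20 log units; within the scatter) and in place of diisopropylamino gives a 2.0-fold lower number from compound 1 to compound 3 (0.30 log units; within the scatter) with no separation from either open-chain amine. The larger ring group, with its added oxygen, is therefore accommodated on this saturated chain carbon. No measurement shown explains this result.

Still open, as far as these compounds go, is whether the hydroxymethyl or the methyl on the ring matters to the number. Also open, from the compounds shown here alone, is how a morpholine, a piperidine or a carboxylic acid would read at this place.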